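The source may hold more compounds than are shown below. What is called first, only, known or untested is meant among the compounds shown, and "the series" means these compounds.

Compound 1 `Cc1ccc(C(=O)CSc2nnc(C)n2N2C(=O)c3ccccc3C2=O)cc1` shows in a functional assay on PC-3M cells (Homo sapiens) for cytotoxicity, read by MTT assay, with a stated time of 48 h (a higher number here means a weaker inhibitor, a lower number a stronger inhibitor), only a limit of the assay, > 200000 nM, as recorded in the limit of > 200000 nM in this assay, at which 1 of the 2 values shown sits. Within the data shown here, compound 2 `COc1cc(-c2nnc(SCC(=O)c3ccc(C)cc3)n2N2C(=O)c3ccccc3C2=O)cc(OC)c1OC` gives in this assay the value 11700 nM, the only real number so far; the step of an at least 17-fold lower number from compound 1 to compound 2 (1.23 log units; beyond the scatter) came with 3,4,5-trimethoxyphenyl in place of methyl on an aromatic carbon. Compound 3 `COc1ccc(C(=O)CSc2nnc(-c3cc(OC)c(OC)c(OC)c3)n2N2C(=O)c3ccccc3C2=O)cc1` differs from compound 2 by methoxy in place of methyl on an aromatic carbon. Among the measured compounds shown here, no measured step covers this kind of exchange, so nothing beyond the usual scatter is expected, and compound 3 is estimated at 10000 nM, between 4000 nM and 30000 nM. The expected step of a 1.2-fold lower number from compound 2 to compound 3 (0.07 log units; within the scatter) is therefore small.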

Compound 3, half-maximal inhibitory concentration: 32800 nM
The estimate for compound 3 lay 3.3-fold (0.52 log units) below the measured number; the measured number lies above the stated range.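

Until now only one other place on the molecule had been changed; this result shows that the 4-methylphenyl end also matters. In this assay, methoxy in place of methyl, para to a large group, gives a 2.8-fold higher number from compound 2 to compound 3 (0.45 log units; beyond the scatter), so even this small exchange weakens the compound beyond the scatter. Nothing given here accounts for the shift. The compounds shown leave open how a chlorine atom, an amine or a plain hydrogen at this position would compare with methyl, and whether a longer chain such as ethoxy would weaken the compound further.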